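The source may report more compounds than this note shows. Statements on the series, on what has been measured and on what is new or still open speak of the compounds shown alone.

Series notes. Two vinyl sulfones have been measured in an assay on U2OS cells for activation of nuclear factor erythroid 2-related factor 2 (Homo sapiens), read by beta-arrestin recruitment, with a stated time of 6 h; on this read-out lower numbers stand for an effect already at smaller amounts and higher numbers for an effect only at larger amounts of compound. Compound 1 `O=S(=O)(/C=C/c1ncccc1Cl)c1ccccc1F` gives 30 nM in this assay. Compound 2 `O=S(=O)(/C=C/c1ncccc1F)c1ccccc1Cl` gives 122 nM in this assay, the highest of the two numbers recorded; its nearest neighbour is compound 1, whose number is lower by a margin beyond the scatter. The two compounds differ in more than one place, so the two values alone are what the comparison shows.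

The next compound, compound 3 `O=S(=O)(/C=C/c1ncccc1Cl)c1ccccc1Cl`, is not yet measured. It differs from compound 2 by chloro in place of fluoro on an aromatic carbon. Without a single-change step between measured compounds, the expected size of the step is uncertain; a decrease in this assay is expected, probably of modest size, near the edge of the scatter, as a 2.4-fold lower number from compound 2 to compound 3 (0.39 log units; beyond the scatter). Compound 3 is therefore estimated at 50 nM in this assay, with a range from 15 nM to 160 nM, partly because compound 1 gives 30 nM.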

Compound 3, half-maximal effective concentration: 26 nM
The estimate for compound 3 lay 1.9-fold (0.28 log units) above the measured number; low and high end bracket the measured number.
By their numbers in this assay, from the lowest: compounds 3 and 1 (each within the scatter of the next); then compound 2.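

In this assay the exchange of fluoro for chloro at this position, on an aromatic carbon two atoms from the ring nitrogen, gives a 4.7-fold lower number from compound 2 to compound 3 (0.67 log units; beyond the scatter) and so is a real step rather than repeat-measurement noise. The same exchange of halogens on the other aromatic ring gives a 1.2-fold lower number from compound 1 to compound 3 (0.06 log units; within the scatter), so among these three compounds the size of the step depends on where the exchange is made, and a single halogen atom at this position is enough to move the number. No available data bear on why the two places differ.

Open, from the compounds shown here alone, is whether this position takes anything other than a halogen, such as a hydrogen, a methoxy group or an amine. Also open, going by these compounds, is whether a bromo group continues the step seen from fluoro to chloro.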